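The source may report more compounds than this note shows. Statements on the series, on what has been measured and on what is new or still open speak of the compounds shown alone.

Compound 1 `Nc1cccc(CCCCCC(=O)N2CCOC2=O)c1` and compound 2 `O=C(CCCCCc1ccc(Br)cc1)N1CCOC1=O` share a core built from a carbon chain that links a six-membered aromatic ring of carbon only to a cyclic amide. In an assay on HEK293 cells for inhibition of N-acylethanolamine-hydrolyzing acid amidase (Rattus norvegicus), read by LC-MS, with a stated time of 30 min (a higher number here means a weaker inhibitor, a lower number a stronger inhibitor), compound 1 gives only a limit, > 20000 nM, rather than a number (the limit of > 20000 nM in this assay, at which 1 of the 2 values shown sits). Compound 2, which carries a bromo group on the aromatic ring, gives 8510 nM in this assay. Within the data shown here, compound 2 thus stands as the sole measured value in this assay; the other entry is a limit.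

Compound 3 `Cc1ccc(CCCCCC(=O)N2CCOC2=O)cc1` differs from compound 2 in one place: methyl in place of bromo on an aromatic carbon. Among the measured compounds shown here, no measured pair shows what this change does. Since bromo and methyl are each a single heavy atom at the same place, the expected step from compound 2 to compound 3 in this assay is a 1.4-fold higher number from compound 2 to compound 3 (0.15 log units; within the scatter), a small move towards a weaker inhibitor that may not exceed the usual scatter. Compound 3 is therefore estimated at 12000 nM, with a range from 4000 nM to 40000 nM.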

Compound 3, half-maximal inhibitory concentration: 440 nM
Estimate against measurement, compound 3: 27-fold (1.44 log units) above; the measured number lies below the stated range.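

In this assay, methyl in place of bromo on an aromatic carbon, para to a large group, gives a 19-fold lower number from compound 2 to compound 3 (1.29 log units; beyond the scatter). This position therefore responds strongly to the choice between two groups that match in heavy-atom count, and neither of which has hydrogen-bond donors, hydrogen-bond acceptors or a net charge. Nothing in the measurements shown accounts for why this swap moves the number so far.

The compounds shown leave open whether methyl is the best choice at this place, or whether an ethyl group, a methoxy group or a plain hydrogen would give a stronger or a weaker inhibitor. They also leave open what a shorter or a longer carbon chain would do on the core of compound 3.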